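Kinetic Solubility Across Three Side-Chain Variants and a Fourth

This account rests on a few compounds, and the source may have more. Where it says the series, first, only, none or still open, it means among the compounds named here.

Compound 1 `CC(C)NC(=O)CC(c1ccc(-c2ccc3cccc(F)c3c2)[nH]c1=O)C(C)C` gives 18000 nM
Compound 2 `CC(C)C(Cc1ncc[nH]1)c1ccc(-c2ccc3cccc(F)c3c2)[nH]c1=O` gives 22100 nM
Compound 3 `CC(C)C(Cc1nnn[nH]1)c1ccc(-c2ccc3cccc(F)c3c2)[nH]c1=O` gives 27300 nM

These three compounds share a core and differ only in the group on a saturated chain carbon, two bonds along the chain from an aromatic carbon. In a physicochemical assay for solubility, in phosphate buffer, measured as kinetic solubility (on this read-out lower numbers stand for lower solubility and higher numbers for higher solubility), compound 3 has the highest of the three numbers shown, yet the steps of a 1.2-fold higher number from compound 2 to compound 3 (0.09 log units; within the scatter) and a 1.5-fold higher number from compound 1 to compound 3 (0.18 log units; within the scatter) both lie within the scatter, so the three values cannot be told apart.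

Compound 4 `CC(C)C(CC(N)=O)c1ccc(-c2ccc3cccc(F)c3c2)[nH]c1=O` is the next member: carbamoyl in place of 1H-tetrazol-5-yl on a saturated chain carbon, two bonds along the chain from an aromatic carbon. The step that bears most on it is the one between the isopropylcarbamoyl and tetrazolyl groups, a 1.5-fold higher number from compound 1 to compound 3 (0.18 log units; within the scatter), which was within the scatter; the step of a 1.2-fold higher number from compound 1 to compound 2 (0.09 log units; within the scatter) was likewise within the scatter. The carbamoyl group of compound 4 resembles the isopropylcarbamoyl group of compound 1, so compound 4 is expected to land near compound 1 and compound 3, with a step of a 1.2-fold lower number from compound 3 to compound 4 (0.09 log units; within the scatter) that stays within the scatter. Compound 4 is therefore estimated at 22000 nM, with a range of 11000 nM to 44000 nM.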

Compound 4, solubility: 5600 nM
Compound 4: the middle estimate sits 3.9-fold (0.59 log units) above what was measured; the whole stated range lies above it.
By their numbers in this assay, from the lowest: compound 4; then compounds 1, 2 and 3 (each within the scatter of the next).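

At this position the group does matter in this assay: the three earlier groups could not be told apart, whereas carbamoyl gives a 4.9-fold lower number from compound 3 to compound 4 (0.69 log units; beyond the scatter) and a 3.9-fold lower number from compound 2 to compound 4 (0.60 log units; beyond the scatter) when it takes the place of the two azole groups. The amide alone does not set the level, since hydrogen in place of isopropyl on an amide-type nitrogen gives a 3.2-fold lower number from compound 1 to compound 4 (0.51 log units; beyond the scatter). Compound 1 stays within the scatter of compounds 2 and 3. No supporting measurement accompanies these results that could account for the drop.

The compounds shown leave open whether a methylcarbamoyl group would stay with carbamoyl or with isopropylcarbamoyl. They also leave open where a carboxylic acid or an amine would fall on the same saturated chain carbon.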